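The compounds below may be only part of what the source reports. "The series", "measured", "known", "first", "only" and "open" are said of these compounds alone.

Measured compounds in the series:

compound 1, `COCc1nc2nc(C)cc(Nc3ccc(C(F)(F)F)cc3)n2n1`, 2.5 in a physicochemical assay for lipophilicity, at pH 7.4; a lower number here means a more polar compound, a higher number a more lipophilic compound
compound 2, `CCc1nc2nc(C)cc(Nc3ccc(C(F)(F)F)cc3)n2n1`, 3
compound 3, `Cc1cc(Nc2ccc(C(F)(F)F)cc2)n2nc(CCO)nc2n1`, 2.2

Compound 3 has the lowest number of the three in this assay; compound 1 lies closest to it, with a number 0.30 log units lower from compound 1 to compound 3 (within the scatter) separating them, and compound 2 lies furthest, with a number 0.80 log units lower from compound 2 to compound 3 (beyond the scatter). Compound 4, `CSc1nc2nc(C)cc(Nc3ccc(C(F)(F)F)cc3)n2n1`, has not yet been measured. It differs from compound 3 in one place: methylsulfanyl in place of 2-hydroxyethyl on an aromatic carbon.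

Among the compounds with values here, two measured steps bear on this change. The step from compound 2 to compound 3, a number 0.80 log units lower from compound 2 to compound 3 (beyond the scatter), shows what adding a hydroxy to the chain did; the step from compound 1 to compound 2, a number 0.50 log units higher from compound 1 to compound 2 (beyond the scatter), shows a carbon chain against an oxygen-bearing one. Within the data shown here, no measured step involves a sulfur, so the size for methylsulfanyl is taken by analogy with the ethyl of compound 2. Compound 4 is expected to run higher than compound 3 by a number 0.70 log units higher from compound 3 to compound 4 (beyond the scatter), a modest step beyond the scatter. The estimate for compound 4 is 2.9, within 2.4 to 3.4.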

Compound 4, distribution coefficient: 3.2
For compound 4 the middle estimate is 0.30 log units below the measured one, within the range that was stated.
By their numbers in this assay, from the lowest: compounds 3 and 1 (each within the scatter of the next); then compounds 2 and 4 (each within the scatter of the next).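

In this assay this position, on an aromatic carbon between two ring nitrogen atoms, now carries a sulfur-bearing group, and methylsulfanyl in place of 2-hydroxyethyl gives a number 1.00 log units higher from compound 3 to compound 4 (beyond the scatter). Methylsulfanyl and ethyl are not separated at this position, with a number 0.20 log units higher from compound 2 to compound 4 (within the scatter), so the sulfur-linked group and the all-carbon chain read alike here. Methylsulfanyl in place of methoxymethyl gives a number 0.70 log units higher from compound 1 to compound 4 (beyond the scatter), which sets compound 2 and compound 4 apart from compound 1 and compound 3, the two compounds with an oxygen-bearing chain, and none of the four goes against this split.

No measurement at hand gives a reason for these steps. From the compounds shown here alone, whether an amine, a methoxy group or a longer chain at this position would fall with either pair remains open.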